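Swapping a fluorophenyl for a dimethoxyphenyl on a thiazole core

A few compounds are considered here, and "the series" means these few. Any claim that something is new, unique, unknown or untested is made for them only; others in the source may bear on it.

Measured compounds:
Compound 1, `Nc1cccc(-c2cn3nc(-c4cccs4)sc3n2)c1`: > 250000 nM
Compound 2, `C=C(Br)C(=O)Nc1cccc(-c2cn3nc(-c4ccc(F)cc4)sc3n2)c1`: 830 nM
Compound 3, `C=C(Br)C(=O)Nc1cccc(-c2cn3c(-c4ccccc4)csc3n2)c1`: 2800 nM

In a functional assay on CCRF-CEM cells (Homo sapiens) for inhibition, read by cell counting, with a stated time of 3 days (a lower number here means a stronger inhibitor, a higher number a weaker inhibitor), compound 1 gives only a limit, > 250000 nM, because of the limit of > 250000 nM in this assay, at which 1 of the 3 values shown sits. Compound 2 has the lower of the two numbers that were actually reached, and the gap to compound 3 lies beyond the usual scatter of this assay. Compound 4, `C=C(Br)C(=O)Nc1cccc(-c2cn3nc(-c4ccc(OC)c(OC)c4)sc3n2)c1`, has not yet been measured. It differs from compound 2 in one place: 3,4-dimethoxyphenyl in place of 4-fluorophenyl on an aromatic carbon. Going by the values given here, no measured pair here isolates such a change, so the expectation rests on compound 2 alone. A modest weakening of inhibition is expected, of the size a 1.8-fold higher number from compound 2 to compound 4 (0.26 log units; within the scatter), though a result within the scatter of compound 2 would not be surprising. For compound 4 the estimated value in this assay is 1500 nM, with a likely range from 400 nM to 6000 nM.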

Compound 4, half-maximal inhibitory concentration: 380 nM
The estimate for compound 4 lay 3.9-fold (0.60 log units) above the measured number; the measured number lies below the stated range.
By their numbers in this assay, from the lowest: compound 4; then compound 2; then compound 3. At a limit, above all of these: compound 1.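

In this assay, replacing 4-fluorophenyl with 3,4-dimethoxyphenyl on an aromatic carbon of the five-membered aromatic ring gives a 2.2-fold lower number from compound 2 to compound 4 (0.34 log units; beyond the scatter). Compound 2 alone could not show how this position responds to a change of its aryl group; this step shows that a group with more heavy atoms and two hydrogen-bond acceptors is accepted there, and that inhibition becomes modestly stronger rather than weaker. Nothing among the results shown explains why the step goes in this direction.

This is a single step, so it sets no trend for the position, and it leaves open whether both methoxy groups are needed. A 4-methoxyphenyl group would address that question, while a morpholine or a simple amine would test whether an aromatic ring is needed there at all.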